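Swapping a Propyl Chain for a Pyridinylmethyl Group

The source may hold more compounds than are shown below. What is called first, only, known or untested is meant among the compounds shown, and "the series" means these compounds.

Measured compounds:
- compound 1, `COc1ccc(C(C)=O)cc1CSc1nc2cc(NC(=O)C3CC3)ccc2n1C(C)C`: 260 nM
- compound 2, `CCCn1c(SCc2cc([N+](=O)[O-])ccc2OC)nc2cc(NC(=O)NC(C)(C)C)ccc21`: 18 nM
- compound 3, `COCCn1c(SCc2cc([N+](=O)[O-])ccc2OC)nc2cc(NC(=O)NC(C)(C)C)ccc21`: 57 nM

All three were tested in an assay on isolated protein for inhibition of Gonadotropin-releasing hormone receptor (Homo sapiens); a higher number here means a weaker inhibitor, a lower number a stronger inhibitor. Among them compound 2 gives the lowest number, so it is the strongest inhibitor of the set; compound 3 sits nearest to it, and compound 1 sits furthest away. For the measured compounds named here, compound 1 differs from compound 2 in several places at once, so its value shows only that those combined changes weaken inhibition.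

Compound 4, `COc1ccc([N+](=O)[O-])cc1CSc1nc2cc(NC(=O)NC(C)(C)C)ccc2n1Cc1cccnc1`, is not yet measured. It differs from compound 2 in one place: pyridin-3-yl in place of ethyl on a saturated chain carbon bound to an aromatic nitrogen. Going by the values given here, the one measured step that touches the same place is a 3.2-fold higher number from compound 2 to compound 3 (0.50 log units; beyond the scatter), where a change on that chain made the inhibitor modestly weaker. Nothing measured here involves an aromatic ring on this chain, so the direction for compound 4 is uncertain; a modest shift in either direction seems most plausible.

Compound 4 is therefore expected to give about 40 nM, within roughly 10 nM to 160 nM. This estimate corresponds to a 2.2-fold higher number from compound 2 to compound 4 (0.35 log units; beyond the scatter).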

Compound 4, half-maximal inhibitory concentration: 33 nM
Beside the measured number, compound 4's estimate is 1.2-fold (0.08 log units) above it; measured number inside the range.
By their numbers in this assay, from the lowest: compounds 2, 4 and 3 (each within the scatter of the next, the first and the last beyond it); then compound 1.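

Exchanging the propyl chain on the aromatic nitrogen for (pyridin-3-yl)methyl gives a 1.8-fold higher number from compound 2 to compound 4 (0.26 log units; within the scatter) and so brings in a six-membered aromatic ring with no change that can be told from the scatter. For the compounds shown here, this is the first sign that this place accepts a ring as well as an open chain. Set against the methoxy-bearing chain of compound 3, the ring gives a 1.7-fold lower number from compound 3 to compound 4 (0.24 log units; within the scatter) and again does not separate the two compounds, and no measurement on hand explains this tolerance.

Still open, as far as these compounds go, is whether the ring nitrogen matters at all, which a plain phenyl ring on the same chain carbon would test, as pyridin-2-yl or pyridin-4-yl would test where that nitrogen sits. From the compounds shown here alone, it is also open whether an amine or a carboxylic acid on this chain would be accepted.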